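A Second Chloro on the Aryl Ring of Compound 1

This account rests on a few compounds, and the source may have more. Where it says the series, first, only, none or still open, it means among the compounds named here.

Compound 1 `O=C(/C=C/c1ccc2c(c1)B(O)OC2)c1ccc(Cl)cc1` stands second highest of the three numbers measured in a functional assay on MDA-MB-231 cells (Homo sapiens) for cytotoxicity, read by MTT assay, with a stated time of 48 h (a higher number here means a weaker inhibitor, a lower number a stronger inhibitor), where compound 1 gives 7900 nM. Its nearest neighbour is compound 2 `O=C(/C=C/c1ccc2c(c1)B(O)OC2)c1ccc(C(F)(F)F)cc1`, which in this assay gives 9200 nM; the step of a 1.2-fold higher number from compound 1 to compound 2 (0.07 log units; within the scatter) lies within the scatter. Furthest away is compound 3 `O=C(/C=C/c1ccc2c(c1)B(O)OC2)c1ccccc1F`, which gives 2200 nM, a modest step of a 3.6-fold lower number from compound 1 to compound 3 (0.56 log units; beyond the scatter) that goes beyond the scatter.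

Compound 4 `O=C(/C=C/c1ccc2c(c1)B(O)OC2)c1ccc(Cl)c(Cl)c1` differs from compound 1 by chloro in place of hydrogen on an aromatic carbon of a six-membered aromatic ring of carbon only, ortho to a chloro group and meta to a large group. Among the measured compounds shown here, no measured step repeats this exact change. The step of a 1.2-fold higher number from compound 1 to compound 2 (0.07 log units; within the scatter) shows that swapping the group already on that ring hardly moves this assay. The step of a 3.6-fold lower number from compound 1 to compound 3 (0.56 log units; beyond the scatter) shows that a different halogen pattern on the same ring can lower the number beyond the scatter, but it is a different change, not an addition. The account therefore expects at most a small step for compound 4 in this assay, within or barely beyond the scatter, leaning if anything toward a lower number. Compound 4 is estimated at 6000 nM, with a range from 2500 nM to 15000 nM, an expected step of a 1.3-fold lower number from compound 1 to compound 4 (0.12 log units; within the scatter).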

Compound 4, half-maximal inhibitory concentration: 3400 nM
Compound 4: middle estimate off by 1.8-fold (0.25 log units), on the high side; the measured number falls inside the stated range.
By their numbers in this assay, from the lowest: compounds 3 and 4 (each within the scatter of the next); then compounds 1 and 2 (each within the scatter of the next).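

In this assay, the addition of a chloro group on an aromatic carbon, ortho to the chloro group already there and meta to a large group, gives a 2.3-fold lower number from compound 1 to compound 4 (0.37 log units; beyond the scatter) and so goes beyond the scatter, whereas the earlier swap of that existing chloro group gives a 1.2-fold higher number from compound 1 to compound 2 (0.07 log units; within the scatter) and stays within it. Among the compounds shown here, this is the first step that keeps the existing chloro group and adds to the ring rather than exchanging what it carries, and it shows that this previously empty position can lower the number, although only by a modest step. Nothing measured here bears on why the number falls at this position.

On these data alone, it remains open whether a group other than chloro at this same position, such as a methoxy group, an amine or a carboxylic acid, would lower the number as well, or would leave it unchanged or raise it. As far as these compounds go, it is also open whether the added chloro group would give a similar step with the original chloro group absent, or with trifluoromethyl in its place.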